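The source may hold more compounds than are shown below. What is called first, only, known or untested is meant among the compounds shown, and "the series" means these compounds.

In an assay on isolated protein for displacement of a labelled ligand from Alpha-1A adrenergic receptor (Homo sapiens) (on this read-out higher numbers stand for weaker inhibition and lower numbers for stronger inhibition), compound 1 `OCc1cc(CN2CCN(c3ccccc3Oc3ccccc3)CC2)on1` gives 1500 nM, while compound 2 `O=C1CCCCN1Cc1cc(CN2CCN(c3ccccc3Oc3ccccc3)CC2)on1` gives 15 nM, the lower of the two numbers; the step between them is a 100-fold lower number from compound 1 to compound 2 (2.00 log units; beyond the scatter). Compound 3 `O=C1CCCCCN1Cc1cc(CN2CCN(c3ccccc3Oc3ccccc3)CC2)on1` differs from compound 2 by 2-oxoazepan-1-yl in place of 2-oxopiperidin-1-yl on a saturated chain carbon bound to an aromatic carbon. For the measured compounds named here, the one measured step traded a hydroxy for the six-membered lactam; compound 3 keeps a lactam and only moves from the six-membered to the seven-membered ring, a change no measured pair tests. The expected step from compound 2 to compound 3 is therefore no change at the digits printed from compound 2 to compound 3 (within the scatter), within the scatter. Compound 3 is estimated at 15 nM, between 5 nM and 45 nM.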

Compound 3, inhibition constant: 86 nM
Compound 3: middle estimate off by 5.7-fold (0.76 log units), on the low side; measured number outside the range, above it.
By their numbers in this assay, from the lowest: compound 2; then compound 3; then compound 1.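

At this position, on a saturated chain carbon bound to an aromatic carbon, lactam ring size matters in this assay: 2-oxoazepan-1-yl in place of 2-oxopiperidin-1-yl gives weaker inhibition (a 5.7-fold higher number from compound 2 to compound 3 (0.76 log units; beyond the scatter)). The larger lactam still clearly outperforms hydroxy (a 17-fold lower number from compound 1 to compound 3 (1.24 log units; beyond the scatter)), so the gain from a lactam survives this ring change, though only in part. Nothing available explains the difference between the two ring sizes.

Two ring sizes cannot show how inhibition changes with ring size, so the five-membered 2-oxopyrrolidin-1-yl remains an open case. Going by these compounds, whether an open-chain amide or an amine could match either lactam also remains open.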